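Working notes: aryl groups on the shared core

This account rests on a few compounds, and the source may have more. Where it says the series, first, only, none or still open, it means among the compounds named here.

In a functional assay on MDA-MB-231 cells (Homo sapiens) for inhibition, read by CCK-8 assay, with a stated time of 48 h (on this read-out higher numbers stand for weaker inhibition of growth and lower numbers for stronger inhibition of growth), the measured compounds read as follows:
- compound 1 `CC(C)c1ccc(Nc2nc(Nc3ccc(N4CCN(C)CC4)cn3)ncc2Cl)cc1` gives 7020 nM
- compound 2 `CN1CCN(c2ccc(Nc3ncc(Cl)c(Nc4ccc(C(C)(C)C)cc4)n3)nc2)CC1` gives 16200 nM
- compound 3 `Cc1cc(C)c(Nc2nc(Nc3ccc(N4CCN(C)CC4)cn3)ncc2Cl)c(C)c1` gives 21000 nM

Compound 3 stands at the high end of these numbers, level with compound 2 (a 1.3-fold higher number from compound 2 to compound 3 (0.11 log units; within the scatter)) and clearly separated from compound 1 (a 3.0-fold higher number from compound 1 to compound 3 (0.48 log units; beyond the scatter)). Compound 4 `COc1cccc(Nc2nc(Nc3ccc(N4CCN(C)CC4)cn3)ncc2Cl)c1` carries 3-methoxyphenyl in place of 2,4,6-trimethylphenyl on a nitrogen on an aromatic ring in the same setting. For the measured compounds named here, those two steps are the closest guide, though no measured compound carries 3-methoxyphenyl. A modest move to a lower number is therefore expected in this assay, reversing part of the step to compound 3. The expected change is a 2.1-fold lower number from compound 3 to compound 4 (0.32 log units; beyond the scatter) and remains uncertain. For compound 4 the expected value is 10000 nM, with 3500 nM to 28000 nM as the estimated range.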

Compound 4, concentration for 50% growth inhibition: 8510 nM
The estimate for compound 4 lay 1.2-fold (0.07 log units) above the measured number; the measured number falls inside the stated range.
By their numbers in this assay, from the lowest: compounds 1, 4, 2 and 3 (each within the scatter of the next, the first and the last beyond it).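

In this assay, for the compounds shown here, 3-methoxyphenyl, the first group here with an oxygen and a hydrogen-bond acceptor, gives a step beyond the scatter from 2,4,6-trimethylphenyl: a 2.5-fold lower number from compound 3 to compound 4 (0.39 log units; beyond the scatter). Against the two alkyl-substituted phenyl groups it cannot be told apart, with a 1.9-fold lower number from compound 2 to compound 4 (0.28 log units; within the scatter) and a 1.2-fold higher number from compound 1 to compound 4 (0.08 log units; within the scatter), both within the scatter. Nothing available bears on why these steps arise.

Open, on these data alone, is whether an amine or a carboxylic acid on this phenyl ring, or a longer chain in place of the methoxy group, would move the number clearly away from that of compound 1.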